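The source may hold more compounds than are shown below. What is called first, only, known or untested is meant among the compounds shown, and "the series" means these compounds.

Compound 1 `C/C=C/C(C)=C/[C@@]1(C)SC(O)=CC1=O` and compound 2 `CC/C=C/C=C/[C@@]1(C)SC(O)=CC1=O` share the same core and differ in the chain attached to it. In a functional assay on MCF7 cells (Homo sapiens) for inhibition, read by radiometric assay and XTT assay (on this read-out lower numbers stand for stronger inhibition and higher numbers for weaker inhibition), compound 1 gives > 80 ug/mL, which is a limit of the assay and not a number. Compound 2 likewise gives > 80 ug/mL, and this too is only a limit. For the measured compounds named here, the data so far therefore consist of the limit of > 80 ug/mL in this assay, at which 2 of the 2 values shown sit, so compound 2 has no exact value and no measured step connects it with compound 1.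

Compound 3 `CCCC/C=C/C=C/[C@@]1(C)SC(O)=CC1=O` differs from compound 2 in one place: ethyl in place of hydrogen on a saturated chain carbon, two bonds along the chain from a double-bonded chain carbon. Ethyl replaces hydrogen on a saturated chain carbon, two bonds along the chain from a double-bonded chain carbon, so that the ethyl end of the chain becomes butyl.

Going by the values given here, with no measured step as a guide, only a modest change towards stronger inhibition is expected in this assay, and another result reported only as a limit is quite possible. The expected change is an at least 1.3-fold lower number from compound 2 to compound 3 (0.12 log units; that floor lies within the scatter). For compound 3 the estimated value is 60 ug/mL, with an expected range from 25 ug/mL to 120 ug/mL.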

Compound 3, half-maximal inhibitory concentration: 60 ug/mL
For compound 3 middle estimate and measured number coincide at the digits printed, and the stated range covers the measured number.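

In this assay compound 3 gives 60 ug/mL, the first exact number among the compounds shown, so lengthening the saturated end of the chain from ethyl to butyl brings the read-out within the range the assay can report. The change from hydrogen to ethyl on a saturated chain carbon, two bonds along the chain from a double-bonded chain carbon, is read as an at least 1.3-fold lower number from compound 2 to compound 3 (0.12 log units; that floor lies within the scatter); this is only a floor, so the true size of the step could be larger, but the floor alone does not show a change beyond the usual scatter. What keeps the step from being read exactly is the upper limit of the assay: the limit of > 80 ug/mL in this assay, at which 2 of the 3 values shown sit.

The compounds shown leave open whether a longer chain, such as hexyl or octyl, would lower the number further or whether the trend would stop at butyl. They also leave open what a polar group at the chain end, such as a hydroxyl, an amine or a carboxylic acid, or a phenyl ring in place of the butyl end, would do to inhibition.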